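Amide variation on the piperidine carboxamide series

The compounds below may be only part of what the source reports. "The series", "measured", "known", "first", "only" and "open" are said of these compounds alone.

Measured compounds in a functional assay on BXPC-3 cells (Homo sapiens) for inhibition, read by MTT assay, with a stated time of 7 days; on this read-out higher numbers stand for weaker inhibition and lower numbers for stronger inhibition:
compound 1 `O=C([C@@H]1CCCN(S(=O)(=O)c2ccc(S(=O)(=O)C3COC3)cc2)C1)N1CCC(F)(F)CC1` gives 361 nM
compound 2 `CCN(CC)S(=O)(=O)c1ccc(S(=O)(=O)N2CCC[C@@H](C(=O)NC3COC3)C2)cc1` gives 13800 nM
compound 3 `CCN(CC)C(=O)c1ccc(S(=O)(=O)N2CCC[C@@H](C(=O)N3CCC(F)(F)CC3)C2)cc1` gives 240 nM

Compound 2 stands highest of the three numbers in this assay, beyond the scatter against both compound 1 and compound 3, and is the weakest inhibitor shown. Within the data shown here, the only single-point step measured is a 1.5-fold lower number from compound 1 to compound 3 (0.18 log units; within the scatter), which concerns the aromatic substituent and not the amide.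

Compound 4 `CCN(CC)S(=O)(=O)c1ccc(S(=O)(=O)N2CCC[C@@H](C(=O)N3CC[C@@H](OC)C3)C2)cc1` carries the change (3-methoxypyrrolidin-1-yl in place of (oxetan-3-yl)amino on a carbonyl carbon). Among the measured compounds shown here, no measured step bears on this change directly; compound 1 and compound 3 both carry a tertiary cyclic amide and give far lower numbers than compound 2, but each differs from compound 2 in two places, so only their values can be compared. On that comparison the tertiary amide of compound 4 is expected to move the number downward, with a sizeable step a 6.9-fold lower number from compound 2 to compound 4 (0.84 log units; beyond the scatter) expected. The estimate for compound 4 in this assay is 2000 nM, with a range from 400 nM to 10000 nM.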

Compound 4, half-maximal inhibitory concentration: 11500 nM
Compound 4: the middle estimate sits 5.8-fold (0.76 log units) below what was measured, and the stated range ends below it.
By their numbers in this assay, from the lowest: compounds 3 and 1 (each within the scatter of the next); then compounds 4 and 2 (each within the scatter of the next).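

In this assay the change to 3-methoxypyrrolidin-1-yl in place of (oxetan-3-yl)amino on a carbonyl carbon gives a 1.2-fold lower number from compound 2 to compound 4 (0.08 log units; within the scatter) and so leaves the number where it was. Among these compounds, this is the first single-point step at this position, and it shows that, in this pair, the swap from 1 hydrogen-bond donor to 0 hydrogen-bond donors, with a larger group and a defined stereocentre, does not by itself separate compound 4 from compound 2. Nothing available gives a reason for this flat step.

Open, on these data alone, is how dimethylamino, or a pyrrolidine carrying a carboxylic acid in place of the methoxy group, would read on this carbonyl carbon of the same core. Also open, as far as these compounds go, is whether the opposite configuration at the methoxy-bearing stereocentre would read the same as compound 4.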